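Swapping an ester for a bromobenzyl group: cytotoxicity expectation

The source may hold more compounds than are shown below. What is called first, only, known or untested is meant among the compounds shown, and "the series" means these compounds.

compound 1, `CCC1(Cc2ccccc2)OS(=O)(=O)C=C1OCC(=O)OC`: > 200000 nM
compound 2, `CCC1(Cc2ccccc2)OS(=O)(=O)C=C1OS(=O)(=O)c1ccc(C)cc1`: 109000 nM
compound 3, `CCC1(Cc2ccccc2)OS(=O)(=O)C=C1OC(c1ccccc1)c1ccccc1`: > 200000 nM

Of the compounds shown here, three with a shared core have been tested in an ADME assay on HEL cells (Homo sapiens) for cytotoxicity, with a stated time of 3 days; on this read-out higher numbers stand for lower toxicity in this test and lower numbers for higher toxicity in this test. For compound 1 the value > 200000 nM is a limit of the assay, not a number. Compound 3 also gives only a limit, > 200000 nM. Compound 2 gives 109000 nM. Compound 1 therefore stands at the limit of > 200000 nM in this assay, at which 2 of the 3 values shown sit. Compound 4, `CCC1(Cc2ccccc2)OS(=O)(=O)C=C1OCc1ccc(Br)cc1`, has not yet been measured; it differs from compound 1 by 4-bromophenyl in place of methoxycarbonyl on a saturated chain carbon bound to an oxygen on an unsaturated carbon. For the measured compounds named here, no measured pair differs in one place, so no measured step guides this change. In this assay the step from compound 1 to compound 4 is expected to be no larger than the usual scatter, in either direction. Compound 4 is expected to give 180000 nM, within 80000 nM to 400000 nM. The expected step is an at least 1.1-fold lower number from compound 1 to compound 4 (0.04 log units; that floor lies within the scatter).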

Compound 4, half-maximal cytotoxic concentration: 171000 nM
Compound 4: the middle estimate sits 1.1-fold (0.02 log units) above what was measured; the measured number falls inside the stated range.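

In this assay, putting 4-bromophenyl in place of methoxycarbonyl on a saturated chain carbon bound to an oxygen on an unsaturated carbon gives an at least 1.1-fold lower number from compound 1 to compound 4 (0.06 log units; that floor lies within the scatter). Compound 1 gives only a limit of the assay: the limit of > 200000 nM in this assay, at which 2 of the 4 values shown sit.

Even so, this place takes a bromine-bearing aromatic ring with no step shown beyond the scatter, and compound 4 gives a measured number rather than a limit.

On these data alone, whether an amine or a carboxylic acid at this place would move the number beyond the scatter stays open. So does the part played by the bromine, since no pair shown isolates it.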